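Moving a Fluorine Around a Phenyl Ring and Clearance

The source may report more compounds than this note shows. Statements on the series, on what has been measured and on what is new or still open speak of the compounds shown alone.

Compound 1 `O=S(=O)(c1ccc(F)c(F)c1)c1cnc2c(F)cccc2c1-c1ccc(F)cc1` and compound 2 `O=S(=O)(c1ccc(F)c(F)c1)c1cnc2c(F)cccc2c1-c1cccc(F)c1` are built on one shared core, while compound 3 `Cc1ccc(S(=O)(=O)c2cnc3cc(F)ccc3c2-c2cccc(F)c2)cc1F` and the still unmeasured compound 4 `Cc1ccc(S(=O)(=O)c2cnc3cc(F)ccc3c2-c2ccc(F)cc2)cc1F` are built on another; how the two cores differ is not broken down here. In an ADME assay on microsomes from liver (Homo sapiens) for metabolic stability, tested at 2.5 uM (on this read-out higher numbers stand for fast clearance and lower numbers for slow clearance), compound 1 gives 0.78 mL/min, and compound 2 gives 1.28 mL/min. Among the measured compounds shown here, the single change between these two, (4-fluorophenyl in place of 3-fluorophenyl on an aromatic carbon), made a step of a 1.6-fold lower number from compound 2 to compound 1 (0.22 log units; within the scatter), a difference small enough to sit inside the usual scatter of the measurement. In this assay compound 3 gives 0.41 mL/min. Compound 4 carries exactly the same change on the other core, (4-fluorophenyl in place of 3-fluorophenyl on an aromatic carbon), and the surroundings of the change are described in the same words for both pairs. The step is therefore expected to be of similar size, and a step of roughly a 1.5-fold lower number from compound 3 to compound 4 (0.17 log units; within the scatter) is estimated, resting on a 1.6-fold lower number from compound 2 to compound 1 (0.22 log units; within the scatter). Compound 4 is thus expected to give about 0.28 mL/min, most likely somewhere between 0.14 mL/min and 0.56 mL/min.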

Compound 4, intrinsic clearance in a liver preparation (reported as CLH), per the amount of preparation that the assay uses: 2.33 mL/min
Compound 4: the middle estimate sits 8.3-fold (0.92 log units) below what was measured; the whole stated range lies below it.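

In this assay, putting 4-fluorophenyl in place of 3-fluorophenyl gives a 5.7-fold higher number from compound 3 to compound 4 (0.75 log units; beyond the scatter), a step larger than the usual scatter of the measurement. The same change therefore cannot be assumed to carry the same result from one core to the other in this series, as the two steps differ by more than the scatter allows: the same change on two cores in this assay, a 1.6-fold lower number (0.22 log units; within the scatter) from compound 2 to compound 1 and a 5.7-fold higher number (0.75 log units; beyond the scatter) from compound 3 to compound 4, 9.3-fold (0.97 log units) apart, beyond the scatter of two such steps. Among the compounds shown here, this does not show which difference between the cores matters, and with only two pairs it cannot tell how the change would behave on any third core.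

The compounds shown leave open whether a phenyl ring carrying chlorine or a methoxy group in place of fluorine would also depend so strongly on the core. For the compounds shown here, they also leave open which part of the core sets the size of the step, a question that would need compounds differing from one another in only one place on the core.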